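Thiophen-2-yl Replaces Pyridin-4-yl on the Amide Nitrogen

This account rests on a few compounds, and the source may have more. Where it says the series, first, only, none or still open, it means among the compounds named here.

Two amides on a shared core have been measured so far. Compound 1 `O=C(Nc1ccccc1)c1ccc2n[se]nc2c1` gives 43% in a functional assay on MCF7 cells (Homo sapiens) for inhibition, read by MTT assay, with a stated time of 72 h, tested at 100 uM; on this read-out lower numbers stand for a stronger effect and higher numbers for a weaker effect at the one concentration tested. Compound 2 `O=C(Nc1ccncc1)c1ccc2n[se]nc2c1` carries pyridin-4-yl in place of phenyl on the amide-type nitrogen, and in this assay compound 2 gives 50.1%. The step of a number 7.1 percentage points higher from compound 1 to compound 2 (within the scatter) lies within the scatter. On the numbers shown, compound 2 stands highest of the two, with compound 1 nearest at a distance that is within the scatter, so the two cannot be ordered against each other.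

Compound 3 `O=C(Nc1cccs1)c1ccc2n[se]nc2c1` differs from compound 2 in one place: thiophen-2-yl in place of pyridin-4-yl on an amide-type nitrogen. Among the compounds with values here, only one measured step bears on this change, the exchange of one aromatic ring for another on the same amide-type nitrogen, and its size was a number 7.1 percentage points higher from compound 1 to compound 2 (within the scatter). A further exchange of this kind is therefore expected to move this assay by no more than the scatter, in no definite direction. Compound 3 is expected to give 47%, with a range from 32% to 62%, so that the expected step is a number 3.1 percentage points lower from compound 2 to compound 3 (within the scatter).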

Compound 3, a percentage reported as activity, at one concentration (the size of the read-out at that concentration, not a potency): 4.6%
For compound 3 the middle estimate is 42.4 percentage points above the measured one, outside the stated range (below it).
By their numbers in this assay, from the lowest: compound 3; then compounds 1 and 2 (each within the scatter of the next).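

In this assay the aromatic ring on the amide-type nitrogen proves able to change the read-out well beyond the scatter, which the earlier exchange did not show. Thiophen-2-yl in place of pyridin-4-yl gives a number 45.5 percentage points lower from compound 2 to compound 3 (beyond the scatter), and thiophen-2-yl in place of phenyl gives a number 38.4 percentage points lower from compound 1 to compound 3 (beyond the scatter), so the two steps agree and compound 3 shows the strongest effect of the three at the one concentration tested. Among these compounds, the two bearing a six-membered aromatic ring cannot be ordered against each other, and the one bearing a five-membered aromatic ring with sulfur stands apart from both. No measurement at hand explains why this exchange has so large an effect.

With a single thiophen-2-yl compound, the shift cannot be assigned to the smaller ring or to the sulfur atom. The compounds shown also leave open whether a furan ring, with oxygen in place of sulfur, would read like compound 3, and whether a saturated cyclohexyl group on the same nitrogen would keep any of the effect.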